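Swapping a Ring-Free Group for Phenylsulfamoyl

This account rests on a few compounds, and the source may have more. Where it says the series, first, only, none or still open, it means among the compounds named here.

Of the compounds shown here, three share one core and have been tested in an assay on cells (Hepatocyte) for inhibition of glucokinase regulatory protein (Mus musculus), with stated times of 20 min and 40 min; a higher number here means that more compound is needed for the effect, a lower number that less compound is needed. Compound 1 `CC#CCC(O)(c1ccc(N2CCN(S(=O)(=O)c3ccc(N)nc3)C[C@@H]2C#CC)cc1)C(F)(F)F` gives 137 nM, which is the lowest of the three numbers. Compound 2 `CC#C[C@H]1CN(S(=O)(=O)c2ccc(N)nc2)CCN1c1ccc(S(=O)(=O)NC)cn1` gives 381 nM in this assay, a gap beyond the usual scatter. Compound 3 `CC#C[C@H]1CN(S(=O)(=O)c2ccc(N)nc2)CCN1c1ncc(C(O)(C(F)(F)F)C(F)(F)F)cn1` gives 2200 nM, the furthest from compound 1 and also beyond the scatter.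

Compound 4 `CC#C[C@H]1CN(S(=O)(=O)c2ccc(N)nc2)CCN1c1ccc(S(=O)(=O)Nc2ccccc2)cc1` has not yet been measured. It differs from compound 1 in one place: a group of 10 heavy atoms (6 carbon, 1 nitrogen, 2 oxygen, 1 sulfur; one six-membered aromatic ring of carbon only) in place of a group of 10 heavy atoms (6 carbon, 1 oxygen, 3 fluorine; no ring), on an aromatic carbon. Among the measured compounds shown here, no measured pair of compounds shows this exact exchange, so the expectation rests on the spread of the three numbers. Compound 2, which carries a smaller sulfonamide-type group on its own core, sits at 381 nM, and compound 4 is expected to land nearer that region than to compound 1. The step from compound 1 to compound 4 is estimated to be upward, a 2.6-fold higher number from compound 1 to compound 4 (0.41 log units; beyond the scatter), clearly beyond the scatter. For compound 4 the estimate in this assay is 350 nM, with a likely range from 110 nM to 1100 nM.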

Compound 4, half-maximal effective concentration: > 12500 nM
Compound 4 gave a limit, no number; the forecaster's own chance of this, stated with the estimate: 5%; at least 35-fold (1.55 log units) between middle value and limit.
By their numbers in this assay, from the lowest: compound 1; then compound 2; then compound 3. At a limit, above all of these: compound 4.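

With the shared core unchanged, the group on this aromatic carbon, para to a large group, has a very large effect in this assay: replacing the ring-free group with phenylsulfamoyl gives an at least 91-fold higher number from compound 1 to compound 4 (1.96 log units; beyond the scatter). Both groups have 10 heavy atoms, so matching that count at this position did not keep the number close to that of compound 1. For compound 4 the result is a limit and not a number, so the true size of the step remains unknown: the limit of > 12500 nM in this assay, at which 1 of the 4 values shown sits.

The compounds shown do not separate the effect of the phenyl ring from that of the sulfonamide link within phenylsulfamoyl. As far as these compounds go, it also remains open how a simple amine, a carboxylic acid or an unsubstituted sulfonamide would behave on this carbon.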